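Moving the Fluorine on the Amide-Linked Phenyl Ring

The compounds below may be only part of what the source reports. "The series", "measured", "known", "first", "only" and "open" are said of these compounds alone.

Measured compounds:
Compound 1, `O=C(CN1CCC(c2cccc[n+]2[O-])CC1)Nc1cccc(Cl)c1Cl`: 180 nM
Compound 2, `O=C(CN1CCC(c2cccc[n+]2[O-])CC1)Nc1ccc(F)cc1`: 85 nM

For the measured compounds named here, in a functional assay on HEK293 cells for agonist activity at D(4) dopamine receptor (Homo sapiens), read by FLIPR (a higher number here means that more compound is needed for the effect, a lower number that less compound is needed), compound 2 gives 85 nM and stands lowest of the two numbers; compound 1 is its only neighbour, and the step of a 2.1-fold lower number from compound 1 to compound 2 (0.33 log units; beyond the scatter) is modest but beyond the scatter. Compound 3, `O=C(CN1CCC(c2cccc[n+]2[O-])CC1)Nc1ccccc1F`, has not yet been measured in this assay. It differs from compound 2 by 2-fluorophenyl in place of 4-fluorophenyl on an amide-type nitrogen. Going by the values given here, the only measured step, from compound 1 to compound 2, exchanges the whole substituted phenyl ring, so it shows that this part of the molecule can shift the number, but no measured pair tests the position of a single fluorine on that ring. Compound 3 is therefore expected to sit near compound 2, with an estimated step of a 1.5-fold higher number from compound 2 to compound 3 (0.18 log units; within the scatter), most likely within the scatter. The estimate for compound 3 is 130 nM, with a range from 40 nM to 450 nM.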

Compound 3, half-maximal effective concentration: 270 nM
Compound 3: the middle estimate sits 2.1-fold (0.32 log units) below what was measured; the range from low to high includes it.
By their numbers in this assay, from the lowest: compound 2; then compounds 1 and 3 (each within the scatter of the next).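

In this assay the place of a single fluorine on the phenyl ring proves to matter: the two compounds hold the same atoms, joined differently, yet 2-fluorophenyl in place of 4-fluorophenyl gives a 3.2-fold higher number from compound 2 to compound 3 (0.50 log units; beyond the scatter) on the same shared core. Moving that one fluorine also removes the edge seen for the 4-fluorophenyl ring, since 2-fluorophenyl in place of 2,3-dichlorophenyl gives a 1.5-fold higher number from compound 1 to compound 3 (0.18 log units; within the scatter) and so leaves these two numbers indistinguishable. Nothing available here explains why the position of the fluorine changes the number.

The compounds shown leave open where 3-fluorophenyl would fall relative to these two fluorine placements. Also open, as far as these compounds go, is how a 4-chlorophenyl or 4-methoxyphenyl group on the same amide-type nitrogen would compare with the 4-fluorophenyl group of compound 2.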